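The source may report more compounds than this note shows. Statements on the series, on what has been measured and on what is new or still open speak of the compounds shown alone.

Series notes. Compound 1 `CC(C)CNc1nc(N)nc2c1ncn2/C=C1/CC1(CO)CO`, compound 2 `CSc1nc(N)nc2c1ncn2/C=C1/CC1(CO)CO` and compound 3 `CCCCOc1nc(N)nc2c1ncn2/C=C1/CC1(CO)CO` share one core and differ only in the group on one aromatic carbon. In an ADME assay on BCBL1 cells (Homo sapiens) for cytotoxicity, with a stated time of 7 days (a higher number here means that more compound is tolerated, a lower number that less compound is tolerated), compound 1 gives only a limit, > 20000 nM. In this assay compound 2 likewise gives only a limit, > 20000 nM. Compound 3 also gives only a limit in this assay, > 20000 nM. Compound 3 thus stands where the other two stand: at the limit, with no number of its own. The steps among them, a step that the two limits leave unreadable from compound 1 to compound 2, a step that the two limits leave unreadable from compound 1 to compound 3 and a step that the two limits leave unreadable from compound 2 to compound 3, carry no readable size, as all three values sit on (the limit of > 20000 nM in this assay, at which 3 of the 3 values shown sit).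

Compound 4 `CNc1nc(N)nc2c1ncn2/C=C1/CC1(CO)CO` is not yet measured. It differs from compound 3 by methylamino in place of butoxy on an aromatic carbon. No measured step reads on this change: isobutylamino, methylsulfanyl and butoxy at this carbon all leave the compound tolerated to the limit, and nothing shown separates them. The estimated step that the limit leaves unreadable from compound 3 to compound 4 is expected to stay within the scatter. Compound 4 is estimated in this assay at 30000 nM, within 15000 nM to 80000 nM, and the result is expected most likely to come back as a limit only.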

Compound 4, half-maximal cytotoxic concentration: 67000 nM
Beside the measured number, compound 4's estimate is 2.2-fold (0.35 log units) below it; low and high end bracket the measured number.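

In this assay no step from compound 1, compound 2 or compound 3 to compound 4 can be read, as those three compounds give only a limit: the limit of > 20000 nM in this assay, at which 3 of the 4 values shown sit.

The compounds shown leave open whether isobutylamino, methylsulfanyl, butoxy and methylamino on this aromatic carbon differ at all in this assay.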